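Swapping chloro for trifluoromethyl on a triazole side ring

A few compounds are considered here, and "the series" means these few. Any claim that something is new, unique, unknown or untested is made for them only; others in the source may bear on it.

Of the compounds shown here, three sharing one core have been measured in a functional assay on PC-12 cells (Rattus norvegicus) for cytotoxicity, read by MTT assay, with stated times of 2 h and 24 h, tested at 10 uM; a lower number here means a weaker effect, a higher number a stronger effect of the compound at the concentration tested. Compound 1 `Oc1cc(C(F)(F)F)ccc1-c1nc(-c2ccccc2O)n(-c2ccc(Cl)cc2)n1` gives 96.1%. Compound 2 `Oc1cc(C(F)(F)F)ccc1-c1nc(-c2ccccc2O)n(-c2ccc(C(F)(F)F)cc2)n1` gives 102%, and compound 3 `Oc1cc(C(F)(F)F)ccc1-c1nc(-c2ccccc2O)n(-c2ccccc2Cl)n1` gives 102%. The difference between compound 1 and compound 2 is trifluoromethyl in place of chloro on an aromatic carbon, and it moved the read-out by a number 5.9 percentage points higher from compound 1 to compound 2 (within the scatter). Compound 1 and compound 3 carry the same atoms joined differently, described as 2-chlorophenyl in place of 4-chlorophenyl on an aromatic nitrogen, and this gave a number 5.9 percentage points higher from compound 1 to compound 3 (within the scatter); between compound 2 and compound 3 the read-out showed no change at the digits printed from compound 2 to compound 3 (within the scatter).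

Compound 4 `Oc1cc(C(F)(F)F)ccc1-c1nc(-c2ccccc2O)n(-c2ccccc2C(F)(F)F)n1` has not yet been measured. It differs from compound 3 by trifluoromethyl in place of chloro on an aromatic carbon. For the measured compounds named here, this is the same kind of change as the one from compound 1 to compound 2, but not the same: there the entering group sat para to a large group, whereas here it sits ortho to a large group, as the two place descriptions state. Because the earlier step was a number 5.9 percentage points higher from compound 1 to compound 2 (within the scatter), the step from compound 3 to compound 4 in this assay is expected to be small, around a number 1 percentage points higher from compound 3 to compound 4 (within the scatter). Compound 4 is therefore estimated to give about 103%, most likely between 90% and 113%.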

Compound 4, a percentage reported as activity, at one concentration (the size of the read-out at that concentration, not a potency): 92.2%
The estimate for compound 4 lay 10.8 percentage points above the measured number; low and high end bracket the measured number.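

In this assay, trifluoromethyl in place of chloro did not behave as one fixed step that can be carried from one core to another: the same change on two cores in this assay, a number 5.9 percentage points higher (within the scatter) from compound 1 to compound 2 and a number 9.8 percentage points lower (within the scatter) from compound 3 to compound 4, 15.7 percentage points apart, beyond the scatter of two such steps. The new step reads a number 9.8 percentage points lower from compound 3 to compound 4 (within the scatter), and the two further comparisons read a number 9.8 percentage points lower from compound 2 to compound 4 (within the scatter) and a number 3.9 percentage points lower from compound 1 to compound 4 (within the scatter), so each step taken alone stays inside the usual spread of repeats, and only the gap between the two matched changes stands out. This rests on just two pairs of compounds, so it shows that the step from one pair cannot simply be reused for the other, but it does not show why the two differ or how the change would behave on any further core.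

The compounds shown leave open how a different group, such as an amine, a nitrile or a carboxylic acid, would read in the place of the chloro on the side ring. They also leave open whether a repeat of these pairs would give the same gap.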